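Hydroxamate series: removing the side chain of compound 2

This account rests on a few compounds, and the source may have more. Where it says the series, first, only, none or still open, it means among the compounds named here.

The series shares the core shown in compound 1 `O=C(NC1(C(=O)NO)CCS(=O)(=O)CC1)c1ccc(C#Cc2ccccc2)cc1` and varies the group that carries the hydroxamic acid. In a physicochemical assay for solubility (a lower number here means a less soluble compound, a higher number a more soluble compound), compound 1 gives 2000 nM. Compound 2 `CSC[C@H](NC(=O)c1ccc(C#Cc2ccccc2)cc1)C(=O)NO` gives 2000 nM in this assay, level with compound 1 at the digits shown, with no change beyond the scatter between the two. Compound 3 `O=C(NC1(C(=O)NO)CCN(Cc2ccccc2)CC1)c1ccc(C#Cc2ccccc2)cc1` returns only a limit in this assay, < 1000 nM, which is a limit of the measurement and not a number (the limit of < 1000 nM in this assay, at which 1 of the 3 values shown sits).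

Compound 4 `O=C(CNC(=O)c1ccc(C#Cc2ccccc2)cc1)NO` is not yet measured in this assay. It differs from compound 2 by hydrogen in place of (methylsulfanyl)methyl on a saturated chain carbon bound to an amide-type nitrogen and a carbonyl carbon. For the measured compounds named here, no pair of measured compounds differing in a single place is available to size this kind of change, so the step can only be expected: the step of a 1.3-fold higher number from compound 2 to compound 4 (0.10 log units; within the scatter) is estimated to be small, within the scatter or at most a modest gain. On that basis compound 4 is expected to give 2500 nM in this assay, with a range from 900 nM to 7000 nM.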

Compound 4, solubility: 21000 nM
For compound 4 the middle estimate is 8.4-fold (0.92 log units) below the measured one, outside the stated range (above it).
By their numbers in this assay, from the lowest: compounds 1 and 2 (each within the scatter of the next); then compound 4. At a limit, below all of these: compound 3.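

At the saturated chain carbon bound to an amide-type nitrogen and a carbonyl carbon, the substituent matters in this assay: hydrogen in place of (methylsulfanyl)methyl gives an 11-fold higher number from compound 2 to compound 4 (1.02 log units; beyond the scatter), a large step. For the compounds shown here, the earlier compounds offered no pair differing in a single place, so this is the first change that can be sized, and it shows that this one side chain alone, with the rest of compound 2 unchanged, moves the read-out well beyond the scatter. Nothing measured here bears on why the step is this large.

As far as these compounds go, whether a methyl group, a longer chain, an amine or a carboxylic acid at the same carbon would keep the gain seen with hydrogen remains open. Also open, from the compounds shown here alone, is how far the step carries over to compound 1 or compound 3, neither of which differs from compound 4 in a single place.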